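The source may report more compounds than this note shows. Statements on the series, on what has been measured and on what is new or still open speak of the compounds shown alone.

Working notes on the series. In an ADME assay on S9 fraction (Rattus norvegicus) for metabolic stability, with a stated time of 60 min (on this read-out lower numbers stand for a less stable compound and higher numbers for a more stable compound), compound 3 (`COCCN1C(=O)CNc2ncc(-c3ccc(C(C)(C)O)nc3)nc21`) gives 89% and, with compound 1 (`O=c1[nH]c2ncc(-c3ccc(-c4nc[nH]n4)cc3)nc2n1CCC1CCOCC1`) at 93% within the scatter of it, belongs to the top pair of the three numbers. Compound 2 (`CC(C)(O)c1ccc(-c2cnc3c(n2)N(CCC2CCOCC2)C(=O)CN3)cn1`) gives 73% and lies lower than compound 3, beyond the scatter.

The next case is compound 4 (`CC(C)(O)c1ccc(-c2cnc3c(n2)N(CC2CCOCC2)C(=O)CN3)cn1`). The change is oxan-4-yl in place of methoxymethyl on a saturated chain carbon bound to an amide-type nitrogen in a ring and reads as oxan-4-yl in place of methoxymethyl on a saturated chain carbon bound to an amide-type nitrogen in a ring.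

For the measured compounds named here, one measured step bears on this: a number 16 percentage points higher from compound 2 to compound 3 (beyond the scatter) is a modest step that exchanges oxan-4-yl and methoxy in the opposite sense. The match is only partial, since that exchange sits two bonds along the chain from the amide-type nitrogen.

In this assay a fall of similar size is therefore expected, with the estimate being a number 13 percentage points lower from compound 3 to compound 4 (beyond the scatter) (just beyond the scatter). Expected for compound 4 is 76% (estimated range 62% to 89%).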

Compound 4, percent of the compound remaining: 83%
Compound 4: the middle estimate sits 7 percentage points below what was measured; the measured number falls inside the stated range.
By their numbers in this assay, from the lowest: compounds 2, 4, 3 and 1 (each within the scatter of the next, the first and the last beyond it).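

In this assay, the exchange of 2-methoxyethyl for (oxan-4-yl)methyl gives a number 6 percentage points lower from compound 3 to compound 4 (within the scatter), so at this position the six-membered ring with its larger heavy-atom count is taken up without a step beyond the scatter. The other new step, oxan-4-yl in place of (oxan-4-yl)methyl on a saturated chain carbon bound to an amide-type nitrogen in a ring, gives a number 10 percentage points higher from compound 2 to compound 4 (within the scatter), which is also not beyond the scatter, so compound 4 cannot be separated from either neighbour and only the gap between compound 2 and compound 3 remains beyond it. Nothing measured here bears on the reason for these numbers.

Still open, from the compounds shown here alone, is whether an amine or a carboxylic acid on this chain, or a longer chain ending in methoxy, would stay within the scatter of compound 3. Also open, going by these compounds, is whether these steps carry over to the core of compound 1.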